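A few compounds are considered here, and "the series" means these few. Any claim that something is new, unique, unknown or untested is made for them only; others in the source may bear on it.

Of the compounds shown here, three sharing one core have been tested in a functional assay on MDA-MB-231 cells (Homo sapiens) for inhibition, read by sulforhodamine B assay, tested at 10 uM; a higher number here means more inhibition at the concentration tested (going by the name of the read-out), a lower number less inhibition. Compound 1 `CC(=O)N1N=C(c2ccc(-n3ccnc3)cc2)CC1c1ccc(N(C)C)cc1` gives 5%, compound 2 `CN(C)c1ccc(C2CC(c3ccc(-n4ccnc4)cc3)=NN2C(=O)c2cc(Cl)cc(Cl)c2)cc1` gives 48.8%, and compound 3 `CN(C)c1ccc(C2CC(c3ccc(-n4ccnc4)cc3)=NN2S(C)(=O)=O)cc1` gives 12%. Compound 3 therefore stands second highest of the three: its gap to compound 1 is within the scatter (a number 7 percentage points higher from compound 1 to compound 3 (within the scatter)), whereas the step of a number 36.8 percentage points lower from compound 2 to compound 3 (beyond the scatter) is large. Compound 4 `CN(C)c1ccc(C2CC(c3ccc(-n4ccnc4)cc3)=NN2S(=O)(=O)c2ccc(C#N)cc2)cc1` differs from compound 3 by 4-cyanophenyl in place of methyl on a sulfonyl sulfur. For the measured compounds named here, the only measured step that also puts a ring in place of methyl, 3,5-dichlorophenyl in place of methyl on a carbonyl carbon, is a number 43.8 percentage points higher from compound 1 to compound 2 (beyond the scatter). By analogy compound 4 is expected to rise, a number 28 percentage points higher from compound 3 to compound 4 (beyond the scatter), with an estimated 40% and a range from 18% to 62%.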

Compound 4, a percentage reported as inhibition, at one concentration (the size of the read-out at that concentration, not a potency): 7.1%
Beside the measured number, compound 4's estimate is 32.9 percentage points above it; measured number below the stated range.
By their numbers in this assay, from the lowest: compounds 1, 4 and 3 (each within the scatter of the next); then compound 2.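

On the sulfonyl sulfur, a ring brings no gain in this assay: 4-cyanophenyl in place of methyl gives only a small difference (a number 4.9 percentage points lower from compound 3 to compound 4 (within the scatter)), unlike 3,5-dichlorophenyl on the carbonyl carbon. The (4-cyanophenyl)sulfonyl group also stays level with acetyl (a number 2.1 percentage points higher from compound 1 to compound 4 (within the scatter)), while replacing the (3,5-dichlorophenyl)carbonyl group with it costs much of the inhibition (a number 41.7 percentage points lower from compound 2 to compound 4 (beyond the scatter)). Nothing available explains this contrast. Going by these compounds, it remains open whether 3,5-dichlorophenyl, plain phenyl or 4-methoxyphenyl on the sulfonyl sulfur would track compound 2 or compound 4, and whether 4-cyanophenyl on the carbonyl carbon would keep the inhibition of compound 2.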